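From Methoxyphenyl to Fluorophenyl on the Shared Core

A few compounds are considered here, and "the series" means these few. Any claim that something is new, unique, unknown or untested is made for them only; others in the source may bear on it.

Two compounds share one core and differ only in the aromatic ring attached to it. Compound 1 `COc1ccc(-c2cn3ccnc3c(-c3ccc4ncn(C5CCCCC5)c4c3)n2)cc1` carries a 4-methoxyphenyl group; in a functional assay on HCT-116 cells (Homo sapiens) for inhibition, read by sulforhodamine B assay, with a stated time of 48 h, tested at 10 uM (a higher number here means more inhibition at the concentration tested (going by the name of the read-out), a lower number less inhibition), compound 1 gives 91.3%. Compound 2 `c1ccc2c(-c3cn4ccnc4c(-c4ccc5ncn(C6CCCCC6)c5c4)n3)cccc2c1` carries a naphthalen-1-yl group instead, and in this assay compound 2 gives 17.9%. Going by the values given here, compound 1 thus stands highest of the two numbers, with compound 2 as its only neighbour, and the step between them, a number 73.4 percentage points lower from compound 1 to compound 2 (beyond the scatter), is the single measured change available.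

Compound 3 `Fc1ccccc1-c1cn2ccnc2c(-c2ccc3ncn(C4CCCCC4)c3c2)n1` is a further variation. It differs from compound 1 in one place: 2-fluorophenyl in place of 4-methoxyphenyl on an aromatic carbon. The measured step bears on it only loosely: that step exchanged 4-methoxyphenyl for naphthalen-1-yl, whereas 2-fluorophenyl keeps one six-membered aromatic ring of carbon only. A loss seems more likely than a gain, but a smaller one, so the expected step in this assay is a number 26.3 percentage points lower from compound 1 to compound 3 (beyond the scatter). Compound 3 is therefore estimated at 65% in this assay, within a range from 30% to 92%.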

Compound 3, a percentage reported as inhibition, at one concentration (the size of the read-out at that concentration, not a potency): 25.8%
Estimate against measurement, compound 3: 39.2 percentage points above; the whole stated range lies above it.
By their numbers in this assay, from the lowest: compounds 2 and 3 (each within the scatter of the next); then compound 1.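

In this assay, 2-fluorophenyl in place of 4-methoxyphenyl on this aromatic carbon gives a number 65.5 percentage points lower from compound 1 to compound 3 (beyond the scatter) and so a large loss does not depend on the two-ring naphthalen-1-yl group: a replacement that keeps one six-membered aromatic ring of carbon only also loses most of the reading. The two replacements cannot be told apart, since the comparison gives a number 7.9 percentage points higher from compound 2 to compound 3 (within the scatter) and that lies within the usual scatter, so among these three compounds only the 4-methoxyphenyl group goes with a high reading. Nothing available explains why this position responds so sharply to the change.

Compound 3 differs from compound 1 both in the atom carried on the ring and in where that atom sits, so these compounds cannot show whether the methoxy group itself or its place on the ring matters more; 4-fluorophenyl and 2-methoxyphenyl would pull those two apart. As far as these compounds go, it also stays open whether another group in the same place, such as 4-hydroxyphenyl or 4-aminophenyl, would keep the high reading of compound 1.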